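Methoxy for Chloro in Two Styryl Sulfones

A few compounds are considered here, and "the series" means these few. Any claim that something is new, unique, unknown or untested is made for them only; others in the source may bear on it.

Compound 1 `COc1ccc(/C=C/S(=O)(=O)Cc2ccc(OC)cc2)cc1`: in a functional assay on DLD-1 cells (Homo sapiens) for antiproliferative activity, read by trypan blue exclusion (a lower number here means a stronger inhibitor, a higher number a weaker inhibitor), compound 1 gives > 20000 nM, which is a limit of the assay and not a number.
Compound 2 `COc1ccc(CS(=O)(=O)/C=C/c2ccc(Cl)cc2)cc1`: in this assay compound 2 gives 3000 nM.
Compound 3 `COc1ccc(CS(=O)(=O)/C=C/c2ccc(F)cc2Cl)cc1`: in this assay compound 3 gives 4000 nM.

Compound 1 and compound 2 differ in one place: methoxy in place of chloro on an aromatic carbon. That change gave an at least 6.6-fold higher number from compound 2 to compound 1 (0.82 log units; beyond the scatter), a weakening that rests on (the limit of > 20000 nM in this assay, at which 1 of the 3 values shown sits), so its full size is not known. Compound 3 carries a different core, and the difference between the two cores is not broken down here. Its value and that of compound 2 lie within the usual scatter of each other.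

Compound 4 `COc1ccc(CS(=O)(=O)/C=C/c2ccc(F)cc2OC)cc1` has not yet been measured. It differs from compound 3 in one place: methoxy in place of chloro on an aromatic carbon. Within the data shown here, this is the same kind of change as the one from compound 2 to compound 1, but not the same: there the methoxy sits para to a large group, here it sits ortho to a large group and meta to a fluoro group.

Taking the weakening seen from compound 2 to compound 1 as the guide, compound 4 is expected to show a 4.5-fold higher number from compound 3 to compound 4 (0.65 log units; beyond the scatter). Compound 4 is therefore estimated at about 18000 nM, within a range from 6000 nM to 60000 nM, with a real chance that only a limit is reported.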

Compound 4, half-maximal inhibitory concentration: 15000 nM
For compound 4 the middle estimate is 1.2-fold (0.08 log units) above the measured one; the range from low to high includes it.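

Replacing chloro with methoxy on an aromatic carbon raised the number again on the second core, with a 3.8-fold higher number from compound 3 to compound 4 (0.57 log units; beyond the scatter) in this assay, so in the two pairs shown the change weakens the compound each time, and both steps lie beyond the usual scatter. In this assay, going by these compounds, compound 1 gives > 20000 nM, which is a limit of the assay and not a number, so the full size of the earlier step is unknown. Two pairs therefore show only that the direction of the change held across these cores, and they do not show that its size carries over: the same change on two cores in this assay, an at least 6.6-fold higher number (0.82 log units; beyond the scatter) from compound 2 to compound 1 and a 3.8-fold higher number (0.57 log units; beyond the scatter) from compound 3 to compound 4; the limit leaves it open whether they differ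

The compounds shown leave open whether the loss belongs to methoxy in particular or would also follow with another group in the same place, ortho to a large group and meta to a fluoro group, such as an amine, a carboxylic acid or a longer chain like ethoxy. They also leave open whether the same replacement of chloro by methoxy would weaken a third core in this assay, which would test the direction seen in these two pairs.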